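A few compounds are considered here, and "the series" means these few. Any claim that something is new, unique, unknown or untested is made for them only; others in the source may bear on it.

Measured compounds:
Compound 1 `CCCCCCCC/C=C\CCCCCCCC(=O)Nc1nnc(S[C@@H]2O[C@H](COC(C)=O)[C@H](OC(C)=O)[C@H](OC(C)=O)[C@H]2OC(C)=O)s1` — a functional assay on SK-OV-3 cells (Homo sapiens) for cytotoxicity, read by MTT assay, with a stated time of 24 h; on this read-out higher numbers stand for weaker inhibition and lower numbers for stronger inhibition: "not active" (no number reported)
Compound 2 `CCCCCCCC(=O)Nc1nnc(S[C@@H]2O[C@H](CO)[C@H](O)[C@H](O)[C@H]2O)s1` — this assay: 56000 nM
Compound 3 `CCCCCCCCCCCCCC(=O)Nc1nnc(S[C@@H]2O[C@H](CO)[C@H](O)[C@H](O)[C@H]2O)s1` — this assay: "not active" (no number reported)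

Compound 1 returns no number in this assay; it is one of two entries in the set that give no single value, the other being compound 3. Only compound 2 gives a measurable value in this assay, at 56000 nM, and compound 2 carries the shorter acyl chain and the free hydroxyl sugar.

The step under consideration goes from compound 1 to compound 4 `CCCCCCCC(=O)Nc1nnc(S[C@@H]2O[C@H](COC(C)=O)[C@H](OC(C)=O)[C@H](OC(C)=O)[C@H]2OC(C)=O)s1`. The change is hydrogen in place of dec-1-en-1-yl on a saturated chain carbon, seven bonds along the chain from a carbonyl carbon. The acetylated sugar is kept; only the acyl chain is cut back to the length seen in compound 2.

Among the measured compounds shown here, no measured step between two compounds covers this change. Among the measured compounds the shorter chain of compound 2 gave a number where the longer chain of compound 3 did not, so a move toward measurable inhibition in this assay is expected, though the acetylated sugar of compound 1 was itself inactive. Compound 4 is expected to give about 80000 nM, between 30000 nM and 250000 nM, with a real chance that only inactivity is reported.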

Compound 4, half-maximal inhibitory concentration: "not active" (no number reported)
For compound 4 the study gives words and no number, so the estimate cannot be set against anything.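

In this assay, among the compounds shown here, compound 1 gives "not active" (no number reported) and compound 4 gives "not active" (no number reported), so no step between them can be read. The compounds shown leave open whether the acetyl groups separate compound 4 from compound 2, which shares its acyl chain. No supporting data bear on this result.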